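Swapping the pyridine ring of compound 2 for a chlorophenyl ring

A few compounds are considered here, and "the series" means these few. Any claim that something is new, unique, unknown or untested is made for them only; others in the source may bear on it.

Of the compounds shown here, three sharing one core have been tested in an assay on MDA-MB-231 cells for binding affinity to C-X-C chemokine receptor type 4 (Homo sapiens), read by immunofluorescence and microscopy, with stated times of 10 min and 30 min; on this read-out lower numbers stand for an effect already at smaller amounts and higher numbers for an effect only at larger amounts of compound. Compound 1 `Cc1ccc(S(=O)(=O)NCc2ccc(CNC(=O)c3ccccc3)cc2)cc1` reaches only the assay limit there, giving > 1000 nM. Compound 3 `Cc1ccc(S(=O)(=O)NCc2ccc(CNC(=O)c3cccc(C)c3)cc2)cc1` gives 1000 nM, and the step of a number no higher from compound 1 to compound 3 (the limit leaves the size open) cannot be sized (the limit of > 1000 nM in this assay, at which 1 of the 3 values shown sits). Compound 2 `O=C(NCc1ccc(CNS(=O)(=O)c2ccccc2)cc1)c1cccnc1` gives 10 nM, the lowest number shown, and the number for compound 3 lies higher by a gap beyond the scatter. Compound 4 `O=C(NCc1ccc(CNS(=O)(=O)c2ccccc2)cc1)c1cccc(Cl)c1` differs from compound 2 only in the change (3-chlorophenyl in place of pyridin-3-yl on a carbonyl carbon). Among the measured compounds shown here, no measured step concerns this kind of exchange; the sole measured step involved a methyl group, so it offers little guidance. Compound 4 is therefore expected to sit at 300 nM, within 30 nM to 3000 nM, meaning an estimated step of a 30-fold higher number from compound 2 to compound 4 (1.48 log units; beyond the scatter) toward weaker binding.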

Compound 4, effective concentration (reported as EC, without a stated level of effect): 1000 nM
Compound 4: the middle estimate sits 3.3-fold (0.52 log units) below what was measured; low and high end bracket the measured number.
By their numbers in this assay, from the lowest: compound 2; then compounds 3 and 4 (each within the scatter of the next).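

Replacing pyridin-3-yl with 3-chlorophenyl on the carbonyl carbon gives a 100-fold higher number from compound 2 to compound 4 (2.00 log units; beyond the scatter). Unlike the earlier methyl step, which cannot be read, this one puts a size on a change at this position, and it shows that the group held by the carbonyl carbon can matter greatly. Nothing shown gives a reason for that size. From the compounds shown here alone, the change removes the ring nitrogen and adds chlorine together, so their separate contributions stay open. Also open, going by these compounds, is how an amine or a carboxylic acid on this ring would read.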